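A few compounds are considered here, and "the series" means these few. Any claim that something is new, unique, unknown or untested is made for them only; others in the source may bear on it.

Compound 3 `CC(C)n1ncc2c(C(=O)Nc3ccccn3)cc(-c3cccs3)nc21` stands at the edge of what an ADME assay on LLC-MK2 cells (Macaca mulatta) for cytotoxicity, read by spectrophotometry and crystal violet staining, with a stated time of 4 days (a higher number here means that more compound is tolerated, a lower number that less compound is tolerated), reports: compound 3 gives > 200000 nM, which is a limit, not a number. Compound 1 `CC(C)n1ncc2c(C(=O)Nc3cccnc3)cc(-c3cccs3)nc21` likewise gives only the limit > 200000 nM in this assay. Compound 2 `CC(C)n1ncc2c(C(=O)Nc3cccc(F)c3F)cc(-c3cccs3)nc21` gives a measured 75000 nM in this assay. The steps of an at least 2.6-fold lower number from compound 1 to compound 2 (0.42 log units; beyond the scatter) and an at least 2.6-fold higher number from compound 2 to compound 3 (0.42 log units; beyond the scatter) both lie beyond the scatter, whereas a step that the two limits leave unreadable from compound 1 to compound 3 cannot be read because of the limit of > 200000 nM in this assay, at which 2 of the 3 values shown sit. Compound 4 `CC(C)n1ncc2c(C(=O)Nc3cc(F)ccc3F)cc(-c3cccs3)nc21` carries the change (2,5-difluorophenyl in place of pyridin-2-yl on an amide-type nitrogen), the counterpart of what separates compound 2 from compound 3, so a lower number in this assay is expected. For compound 4 a step of an at least 2.6-fold lower number from compound 3 to compound 4 (0.42 log units; beyond the scatter) is expected, at least modest. Compound 4 is therefore estimated at 75000 nM, with a range from 30000 nM to 200000 nM.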

Compound 4, half-maximal cytotoxic concentration: 100000 nM
Estimate against measurement, compound 4: 1.3-fold (0.12 log units) below, within the range that was stated.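

In this assay, the 2,5-difluorophenyl and 2,3-difluorophenyl groups on the amide-type nitrogen read alike, with a 1.3-fold higher number from compound 2 to compound 4 (0.12 log units; within the scatter). Against the pyridinyl amides, the second difluorophenyl group gives an at least 2.0-fold lower number from compound 3 to compound 4 (0.30 log units; that floor lies within the scatter) and an at least 2.0-fold lower number from compound 1 to compound 4 (0.30 log units; that floor lies within the scatter). These two steps are floors only, so the true gap stays unread because of the assay limit: the limit of > 200000 nM in this assay, at which 2 of the 4 values shown sit.

Where a plain phenyl or a pyridin-4-yl on the same nitrogen would fall in this assay remains open. So does whether a single fluorine on the phenyl ring would read like the difluorophenyl groups.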